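This account rests on a few compounds, and the source may have more. Where it says the series, first, only, none or still open, it means among the compounds named here.

Measured so far in a functional assay on HCT-116 cells (Homo sapiens) for cytotoxicity, with a stated time of 3 days; on this read-out higher numbers stand for weaker inhibition and lower numbers for stronger inhibition:
- compound 1 `Cn1c(I)nc2ccccc21`: 17500 nM
- compound 2 `Cn1cnc2ccccc21`: > 40000 nM
- compound 3 `C#Cc1nc2ccccc2n1C`: 19400 nM

The entry for compound 2 is a limit of the assay and not a number. That leaves two true numbers, and compound 3 stands level with compound 1 on them. The measured step between the two is a 1.1-fold higher number from compound 1 to compound 3 (0.04 log units; within the scatter).

The next structure is compound 4 `Cn1c(Br)nc2ccccc21`, with bromo in place of ethynyl on an aromatic carbon.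

Among the compounds with values here, three measured steps bear on this change. Removing the iodo group gives an at least 2.2-fold higher number from compound 1 to compound 2 (0.35 log units; beyond the scatter), and adding ethynyl to the bare core gives an at least 2.0-fold lower number from compound 2 to compound 3 (0.31 log units; beyond the scatter). Both of these steps rest on the limit. Across these three compounds, either group at this carbon gives a measurable number, while hydrogen does not. Exchanging one group for the other changes little, as a 1.1-fold higher number from compound 1 to compound 3 (0.04 log units; within the scatter) shows. Bromo has not yet been tested, but it is a halogen like the iodo of compound 1, so compound 4 is expected to sit with that pair in this assay.

No change beyond the scatter is expected, and the estimated step is a 1.0-fold higher number from compound 3 to compound 4 (0.01 log units; within the scatter). The estimated value for compound 4 is 20000 nM, with an expected range of 11000 nM to 38000 nM.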

Compound 4, half-maximal inhibitory concentration: > 40000 nM
Compound 4 ended at the assay's limit; the forecaster's own chance of this, stated with the estimate: 12%; middle value at least 2.0-fold (0.30 log units) from the limit.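

In this assay compound 4 gives > 40000 nM, which is a limit of the assay and not a number. This shows that a halogen at this carbon does not in itself give a measurable number: bromo in place of iodo gives an at least 2.2-fold higher number from compound 1 to compound 4 (0.35 log units; beyond the scatter), and bromo in place of ethynyl gives an at least 2.0-fold higher number from compound 3 to compound 4 (0.31 log units; beyond the scatter), so the two groups that stood level in compound 1 and compound 3 are both set apart from bromo. Compound 4 therefore cannot be told apart from compound 2, which carries hydrogen at this carbon, and the step between these two cannot be read: the limit of > 40000 nM in this assay, at which 2 of the 4 values shown sit.

Among the compounds shown, only iodo and ethynyl give a true number at this carbon, so it stays open whether chloro, a nitrile or a longer alkynyl chain would give a number in this assay or would also end at the limit. Going by these compounds, it is also open how the numbers would respond if the methyl group that all four compounds carry were exchanged for a longer chain.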